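This account rests on a few compounds, and the source may have more. Where it says the series, first, only, none or still open, it means among the compounds named here.

Measured compounds in a functional assay on A549 cells (Homo sapiens) for inhibition, read by MTT assay, with a stated time of 24 h; a lower number here means a stronger inhibitor, a higher number a weaker inhibitor:
compound 1 `CCOC(=O)c1c(C)[nH]c(=O)c(C#N)c1-c1ccccc1` — > 100000 nM, a limit of the assay rather than a number.
compound 2 `CCOC(=O)c1c(C)[nH]c(=O)c(C#N)c1-c1ccc(F)cc1` — 15400 nM.

Among the measured compounds shown here, compound 2 holds the only numerical value in this assay; the other entry is a limit. The step of an at least 6.4-fold lower number from compound 1 to compound 2 (0.81 log units; beyond the scatter) rests on (the limit of > 100000 nM in this assay, at which 1 of the 2 values shown sits), so only its lower bound is known. Compound 3 `CCOC(=O)c1c(C)[nH]c(=O)c(C#N)c1-c1ccc(Br)cc1` differs from compound 2 by bromo in place of fluoro on an aromatic carbon. For the measured compounds named here, the one measured step touches the same position, hydrogen to fluoro, and it lowered the number at least modestly; no measured step compares one halogen with another at that position. Since a halogen is kept in compound 3, the value is expected to stay near that of compound 2. The estimated step of a 1.7-fold lower number from compound 2 to compound 3 (0.23 log units; within the scatter) is expected to fall within the scatter. Compound 3 is therefore estimated at 9000 nM in this assay, with a range of 2500 nM to 35000 nM.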

Compound 3, half-maximal inhibitory concentration: > 100000 nM
Compound 3 gave a limit, no number (the forecaster's own chance of this, stated with the estimate: 5%); middle value at least 11-fold (1.04 log units) from the limit.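

In this assay, the change from 4-fluorophenyl to 4-bromophenyl gives an at least 6.4-fold higher number from compound 2 to compound 3 (0.81 log units; beyond the scatter), so this position distinguishes one halogen from another, and the lowering seen in an at least 6.4-fold lower number from compound 1 to compound 2 (0.81 log units; beyond the scatter) does not carry over to every halogen. Compound 3 gives > 100000 nM, a limit of the assay, and its step from compound 1 cannot be read, as both values are limits. Only compound 2 gives a number, so the reading of this position rests on a single value set against two limits: the limit of > 100000 nM in this assay, at which 2 of the 3 values shown sit.

On these data alone, how chloro or a small group such as methoxy or an amine would read at this place remains open. Also open, as far as these compounds go, is whether the fluoro result holds when the ethyl ester of the shared core gives way to a carboxylic acid or an amide.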